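The compounds below may be only part of what the source reports. "The series", "measured", "known", "first", "only" and "open" are said of these compounds alone.

In a functional assay on MDA-MB-468 cells (Homo sapiens) for antiproliferative activity, read by MTT assay, with a stated time of 72 h (on this read-out lower numbers stand for stronger inhibition and higher numbers for weaker inhibition), compound 1 `COc1cc(-c2nccn2CC(C)C)cc(OC)c1OC` gives > 100000 nM, which is a limit and not a number. Compound 2 `COc1cc(-c2nccn2S(=O)(=O)c2ccc(C)cc2)cc(OC)c1OC` gives > 100000 nM, again a limit. Compound 1 and compound 2 therefore share (the limit of > 100000 nM in this assay, at which 2 of the 3 values shown sit). Only compound 3 `COc1cc(-c2nccn2-c2ccc3[nH]ccc3c2)cc(OC)c1OC` gives a true number, 2300 nM.

Compound 4 `COc1cc(-c2nccn2-c2cccc(C)c2)cc(OC)c1OC` has not been measured yet. Going from compound 1 to compound 4, 3-methylphenyl takes the place of isobutyl on an aromatic nitrogen: 3-methylphenyl in place of isobutyl on an aromatic nitrogen.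

Among the measured compounds shown here, no measured step between closely related compounds is available here, so the expectation rests on thin evidence. Compound 3 also carries a ring-bearing group on that nitrogen and gives 2300 nM, which suggests that a ring there can be compatible with measurable activity. Compound 2 goes against this suggestion, since it too carries a ring-bearing group there and gives > 100000 nM, a limit.

On balance, a clear step towards stronger inhibition is expected in this assay, though compound 4 could still stay weak. The estimated step is an at least 8.3-fold lower number from compound 1 to compound 4 (0.92 log units; beyond the scatter). Compound 4 is expected to give 12000 nM, with an estimated range from 2500 nM to 60000 nM.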

Compound 4, half-maximal inhibitory concentration: 22600 nM
Compound 4: the middle estimate sits 1.9-fold (0.27 log units) below what was measured; the measured number falls inside the stated range.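

In this assay, putting 3-methylphenyl in place of isobutyl on the aromatic nitrogen gives an at least 4.4-fold lower number from compound 1 to compound 4 (0.64 log units; beyond the scatter). Among the compounds shown here, this is the first single change that can be read, and it takes the compound from no measurable potency to a true number. Only a minimum can be given for the size of the step, since compound 1 gives > 100000 nM, a limit and not a number, and this limit recurs in the series: the limit of > 100000 nM in this assay, at which 2 of the 4 values shown sit. Compound 3 gives 2300 nM and compound 4 gives 22600 nM, so both compounds with an aromatic ring bonded directly to this nitrogen give true numbers, whereas compound 2, with its ring held on a sulfonyl group, goes against any simple rule that a ring-bearing group is enough.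

Going by these compounds, it remains open whether the ring alone accounts for the step or whether its methyl group contributes, which a plain phenyl group at this nitrogen would help to separate. Also open, on these data alone, is how this position would respond to a phenyl ring carrying an amine or a carboxylic acid, or to a chain longer than isobutyl.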